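Amine swap on a quinoline-like amide: from aryl to alkyl

The compounds below may be only part of what the source reports. "The series", "measured", "known", "first", "only" and "open" are said of these compounds alone.

Measured so far:
- compound 1, `CS(=O)(=O)Oc1c(C(=O)NCc2ccc(F)cc2)nc(Br)c2cccnc12`: > 20000 nM
- compound 2, `Nc1ccc(Nc2c(C(=O)NCc3ccc(F)cc3)nc(Br)c3cccnc23)cc1`: 7000 nM
- compound 3, `CS(=O)(=O)NCCCCCCN(c1nc(C(=O)NCc2ccc(F)cc2)c(O)c2ncccc12)S(C)(=O)=O`: 4000 nM

In a functional assay on HCT-116 cells (Homo sapiens) for cytotoxicity, read by MTT assay, with a stated time of 72 h (on this read-out higher numbers stand for weaker inhibition and lower numbers for stronger inhibition), compound 1 sits at a limit of the assay, > 20000 nM, so its inhibition is only known to be weak. Compound 2 gives 7000 nM, the highest of the two actual numbers. Compound 3 gives 4000 nM, and the gap between compound 3 and compound 2 lies within the scatter, so the two cannot be told apart.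

Compound 4, `CNCCCNc1c(C(=O)NCc2ccc(F)cc2)nc(Br)c2cccnc12`, has not yet been measured. It differs from compound 2 as follows: 3-(methylamino)propyl in place of 4-aminophenyl on a nitrogen on an aromatic ring.

Among the measured compounds shown here, the only measured step, an at least 2.8-fold lower number from compound 1 to compound 2 (0.45 log units; beyond the scatter), concerns a different change at the same aromatic carbon and is open-ended, because compound 1 sits at the limit (the limit of > 20000 nM in this assay, at which 1 of the 3 values shown sits). For the measured compounds named here, no measured step exchanges one amine substituent for another, so nothing here shows whether a chain in place of a ring moves the number. Compound 3, which carries a long chain rather than a ring, gives a number close to that of compound 2, which argues for little change.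

Compound 4 is therefore expected to land near compound 2, with the estimated step of a 1.2-fold lower number from compound 2 to compound 4 (0.07 log units; within the scatter) being within the scatter. The estimate for compound 4 is 6000 nM, expected to fall between 1500 nM and 20000 nM.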

Compound 4, half-maximal inhibitory concentration: > 10000 nM
Compound 4 gave a limit, no number; the forecaster's own chance of this, stated with the estimate: 15%; middle value at least 1.6-fold (0.22 log units) from the limit.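

Among the compounds shown here, this is the first comparison at this position in which one amine-bearing group replaces another on the nitrogen on the aromatic ring, and in this assay it gives an at least 1.4-fold higher number from compound 2 to compound 4 (0.15 log units; that floor lies within the scatter). From the compounds shown here alone, that step is only a floor, and the true size of the change stays unknown, because compound 4 sits at a limit of the assay: the limit of > 10000 nM in this assay, at which 1 of the 4 values shown sits. Exchanging 4-aminophenyl for the open 3-(methylamino)propyl chain therefore gives no sign of stronger inhibition of the cells, but it does not establish a real loss either, while the step from compound 1 to compound 4 joins two limits and cannot be read.

Going by these compounds, what remains open is which part of the 4-aminophenyl group matters: a plain phenyl on the same nitrogen would test the ring without its amine, and a 3-hydroxypropyl chain would test a chain without one. A longer chain such as 6-aminohexyl on this nitrogen would add a test of whether chain length changes the result when everything else in the core stays the same.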